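Swapping the pyrrole ketone for a fluorophenyl ketone

The source may report more compounds than this note shows. Statements on the series, on what has been measured and on what is new or still open speak of the compounds shown alone.

Measured compounds:
compound 1 `Cn1cccc1C(=O)/C=C/c1ccc2c(c1)B(O)OC2`: > 100000 nM
compound 2 `O=C(/C=C/c1ccc2c(c1)B(O)OC2)c1ccc([N+](=O)[O-])cc1`: 9100 nM
compound 3 `CCOC(=O)c1ccc(C(=O)/C=C/c2ccc3c(c2)B(O)OC3)cc1`: 7600 nM

In a functional assay on HCT-116 cells (Homo sapiens) for cytotoxicity, read by MTT assay, with a stated time of 48 h (on this read-out lower numbers stand for stronger inhibition and higher numbers for weaker inhibition), compound 1 reaches only the limit (the limit of > 100000 nM in this assay, at which 1 of the 3 values shown sits), so no number is known for it. Compound 2 gives 9100 nM and compound 3 gives 7600 nM in this assay, and the step of a 1.2-fold lower number from compound 2 to compound 3 (0.08 log units; within the scatter) shows that exchanging one aromatic substituent for another left the result unchanged. The new compound 4 `O=C(/C=C/c1ccc2c(c1)B(O)OC2)c1cccc(F)c1` differs from compound 1 by 3-fluorophenyl in place of 1-methyl-1H-pyrrol-2-yl on a carbonyl carbon. For the measured compounds named here, no measured step covers this change directly. Since compounds 2 and 3, both carrying a six-membered carbon ring on the carbonyl, give numbers, compound 4 is expected to fall in the same region, and the expected step is an at least 6.6-fold lower number from compound 1 to compound 4 (0.82 log units; beyond the scatter). Compound 4 is estimated at 15000 nM, between 5000 nM and 60000 nM.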

Compound 4, half-maximal inhibitory concentration: 6700 nM
Compound 4: the middle estimate sits 2.2-fold (0.35 log units) above what was measured, and the stated range covers the measured number.
By their numbers in this assay, from the lowest: compounds 4, 3 and 2 (each within the scatter of the next). At a limit, above all of these: compound 1.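

The group on the carbonyl carbon clearly matters in this assay: 3-fluorophenyl in place of 1-methyl-1H-pyrrol-2-yl gives an at least 14-fold lower number from compound 1 to compound 4 (1.17 log units; beyond the scatter), whereas the earlier step, a swap on an aromatic carbon, stayed within the scatter. This is the first single change shown at this position that moves the result. The true size of the step is unknown, since the value for compound 1 is only a limit: the limit of > 100000 nM in this assay, at which 1 of the 4 values shown sits.

The compounds shown leave open whether the fluorine or the carbon ring carries this step, which an unsubstituted phenyl would help separate. Going by these compounds, how a ring bearing an amine would behave here also remains open.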